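This account rests on a few compounds, and the source may have more. Where it says the series, first, only, none or still open, it means among the compounds named here.

Compound 1 `CCOC(=O)[C@]1(C(=O)Nc2ccccc2)C[C@H]1c1cc(OC)c(OC)c(OC)c1` is the starting point here. In a functional assay on HeLa cells (Homo sapiens) for cytotoxicity, read by MTT assay, with a stated time of 48 h (a higher number here means a weaker inhibitor, a lower number a stronger inhibitor), compound 1 gives > 100000 nM, and this is a limit of the assay rather than a measured number. Two close relatives were measured. Compound 2 `CCOC(=O)[C@]1(C(=O)Nc2ccccc2Cl)C[C@H]1c1cc(OC)c(OC)c(OC)c1` in this assay gives 42400 nM, and compound 3 `COc1cc([C@@H]2C[C@]2(CO)C(=O)Nc2ccccc2)cc(OC)c1OC` in this assay gives 32000 nM. Both steps away from compound 1 go in the same direction: an at least 2.3-fold lower number from compound 1 to compound 2 (0.37 log units; beyond the scatter), and an at least 3.1-fold lower number from compound 1 to compound 3 (0.49 log units; beyond the scatter). Each is known only as a lower bound because the limit of > 100000 nM in this assay, at which 1 of the 3 values shown sits, is where compound 1 sits.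

Compound 4 `CCOC(=O)[C@@]1(C(=O)Nc2ccccc2)C[C@@H]1c1cc(OC)c(OC)c(OC)c1` has not yet been measured. It differs from compound 1 as follows: the two compounds have the same atoms and bonds and differ only in configuration as drawn: 2 of 2 stereo elements differ (all stereocentres are inverted: mirror images); a stereocentre at a saturated ring carbon is drawn R in compound 1 and S in compound 4; a stereocentre at a saturated ring carbon is drawn S in compound 1 and R in compound 4. Neither measured step bears on this change, since both of them alter a group while keeping the configuration of the shared core, whereas from compound 1 to compound 4 no atom is added or removed. There is therefore no measured guide to how large a step, or in which direction, the mirror image brings in this assay; a step not beyond the scatter is the plainest expectation. Compound 4 is accordingly expected to stay near the starting limit, with a number no higher from compound 1 to compound 4 (the limit leaves the size open) as the estimated step. For compound 4 the estimated value is 100000 nM, within a range from 30000 nM to 300000 nM.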

Compound 4, half-maximal inhibitory concentration: > 100000 nM
Compound 4 was reported as a limit (the forecaster's own chance of this, stated with the estimate: 65%); the middle value lies on the limit itself.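

No step can be read between compound 1 and compound 4, because both are reported only as the same assay limit, not as measured numbers: the limit of > 100000 nM in this assay, at which 2 of the 4 values shown sit.

The compounds shown leave open whether these two mirror images differ in cytotoxicity at all, and whether the chloro or hydroxymethyl change would lower the number for compound 4 as well.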